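A fluorine added to the phenyl of compound 3

The source may hold more compounds than are shown below. What is called first, only, known or untested is meant among the compounds shown, and "the series" means these compounds.

Three compounds have been measured in an in vitro assay on HEK385-7 cells for displacement of a labelled ligand from prostaglandin D2 receptor 2 (Homo sapiens); a higher number here means a weaker inhibitor, a lower number a stronger inhibitor:
Compound 1, `O=C(O)Cc1sc(NCc2ccccc2)nc1-c1ccc(Cl)cc1`, gives 440 nM.
Compound 2, `O=C(O)Cc1sc(C2COc3ccccc3O2)nc1-c1ccc(Cl)cc1`, gives 500 nM.
Compound 3, `O=C(O)Cc1sc(C(c2ccccc2)c2ccccc2)nc1-c1ccccc1`, gives 570 nM.

Compound 3 carries the highest of the three numbers, yet its gaps to compound 2 and to compound 1 both lie within the usual scatter of this assay, so the three compounds cannot be ranked against one another on these data; none of them is shown to be stronger or weaker than the others.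

Compound 4, `O=C(O)Cc1sc(C(c2ccccc2)c2ccccc2)nc1-c1cccc(F)c1`, has not yet been measured. It differs from compound 3 in one place: fluoro in place of hydrogen on an aromatic carbon. The new fluoro sits on a six-membered aromatic ring of carbon only, meta to a large group, and the substituted ring reads as 3-fluorophenyl where compound 3 has phenyl.

Within the data shown here, no measured pair in this set shows what a fluoro in place of a ring hydrogen does in this assay, so there is no precedent to lean on. A single halogen added at such a position is expected to move the number little; the estimated step is a 1.1-fold lower number from compound 3 to compound 4 (0.06 log units; within the scatter), which is taken to stay within the scatter. Compound 4 is therefore expected to give about 500 nM, within a range from 220 nM to 1150 nM.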

Compound 4, half-maximal inhibitory concentration: 2.9 nM
Beside the measured number, compound 4's estimate is 170-fold (2.24 log units) above it; measured number outside the range, below it.
By their numbers in this assay, from the lowest: compound 4; then compounds 1, 2 and 3 (each within the scatter of the next).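

In this assay, replacing one ring hydrogen with fluoro gives a 200-fold lower number from compound 3 to compound 4 (2.29 log units; beyond the scatter), so this aromatic carbon, meta to a large group, is a place where a single added heavy atom can change the result far beyond the scatter. Among these compounds, the earlier compounds could not show this, as no two of them differ in only one place and their values lie within the scatter of each other. The group that enters has no ring, no hydrogen-bond donors or acceptors and no net charge, and nothing available here explains how the change from phenyl to 3-fluorophenyl produces a step of this size.

This single pair leaves open whether the step is specific to fluoro or would also appear with a chloro, a methyl or a methoxy group on the same carbon, and whether fluoro on the other carbons of this ring would do the same. It also leaves open whether 3-fluorophenyl would have a similar effect with the different groups carried by compound 1 and compound 2.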